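The source may report more compounds than this note shows. Statements on the series, on what has been measured and on what is new or still open speak of the compounds shown alone.

Measured compounds:
compound 2 `N#Cc1ccc(Cn2ccnn2)cc1` — 100 nM
compound 1 `N#Cc1ccc(C(c2ccc(C#N)cc2)n2cc(COc3ccc(-c4ccccc4)cc3)nn2)cc1` — 13400 nM

In an assay on isolated protein for inhibition of Aromatase (Homo sapiens), read by fluorescence and colorimetric assay, with a stated time of 30 min (on this read-out higher numbers stand for weaker inhibition and lower numbers for stronger inhibition), compound 2 gives 100 nM, the lower of the two numbers. Compound 1, which carries a second nitrile-bearing aryl ring on the methine and a large substituent on the five-membered ring, gives 13400 nM in this assay, a far weaker result that lies well beyond the scatter. Within the data shown here, compound 1 differs from compound 2 in more than one place, so the two values show only that the heavily substituted analogue is much less active, not which change is responsible.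

Compound 3 `N#Cc1ccc(Cn2cc(C3CCCCC3)nn2)cc1` is not yet measured. It keeps the core of compound 2 and introduces (cyclohexyl in place of hydrogen on an aromatic carbon). Among the measured compounds shown here, no measured pair isolates such a change. Given that compound 1 with its large group at that position gives 13400 nM, a moderate loss relative to compound 2 is expected, without reaching the weakness of compound 1. The step from compound 2 to compound 3 is estimated as a 3.0-fold higher number from compound 2 to compound 3 (0.48 log units; beyond the scatter). In this assay compound 3 is expected to give about 300 nM, with a plausible range from 80 nM to 1500 nM.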

Compound 3, half-maximal inhibitory concentration: 10700 nM
For compound 3 the middle estimate is 36-fold (1.55 log units) below the measured one, and the stated range ends below it.
By their numbers in this assay, from the lowest: compound 2; then compounds 3 and 1 (each within the scatter of the next).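

The step is a 110-fold higher number from compound 2 to compound 3 (2.03 log units; beyond the scatter) in this assay, and it comes from a single change: cyclohexyl in place of hydrogen on the aromatic carbon of the five-membered ring. Compound 1 differs from compound 2 in more than one place, so that earlier pair could not tie a loss to any one site, whereas this pair ties a large loss to this carbon and this group. The measured data give no account of why cyclohexyl here has so large an effect.

The compounds shown leave open whether the loss is particular to cyclohexyl or would also follow from another group on the same aromatic carbon, such as a methyl, a phenyl, a hydroxymethyl or an amine. Among these compounds, they also leave open what the second nitrile-bearing aryl ring on the methine of compound 1 does on its own, as no pair of compounds isolates that change.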